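This account rests on a few compounds, and the source may have more. Where it says the series, first, only, none or still open, it means among the compounds named here.

Of the compounds shown here, three built on a shared core have been tested in a functional assay on the whole organism for antagonist activity, with Mus musculus as the target; on this read-out lower numbers stand for an effect already at smaller amounts and higher numbers for an effect only at larger amounts of compound. Compound 1 `COc1cc(N)c(Cl)cc1NC(=O)C1CCN(Cc2ccccc2Cl)CC1` reaches only a limit of the assay, > 4 mg/kg. Compound 2 `COc1cc(N)c(Cl)cc1NC(=O)C1CCN(Cc2ccccc2)CC1` gives 0.5 mg/kg in this assay. Compound 3 `COc1cc(N)c(Cl)cc1NC(=O)C1CCN(C/C=C/c2ccccc2)CC1` likewise stops at a limit of the assay, > 10 mg/kg. Going by the values given here, compound 2 therefore holds the only number among the three; the two other values are limits. Removing the chloro gave an at least 8.0-fold lower number from compound 1 to compound 2 (0.90 log units; beyond the scatter), a clear gain. Lengthening the group on the ring nitrogen gave an at least 20-fold higher number from compound 2 to compound 3 (1.30 log units; beyond the scatter), a large loss. Between compound 1 and compound 3 the step is a step that the two limits leave unreadable from compound 1 to compound 3.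

Compound 4 `COc1cc(N)c(Cl)cc1NC(=O)C1CCN(Cc2ccc(O)cc2)CC1` differs from compound 2 by hydroxy in place of hydrogen on an aromatic carbon. Among the compounds with values here, no measured step carries this exact change, but both measured steps alter the same benzyl group, and each departure from the plain benzyl of compound 2 raised the number: compound 1 with its chloro and compound 3 with its longer chain. A hydroxy on the ring is accordingly expected to cost some potency, though less than those steps, so the expected change is a 2.4-fold higher number from compound 2 to compound 4 (0.38 log units; beyond the scatter). Compound 4 is thus estimated at 1.2 mg/kg, within a range from 0.4 mg/kg to 4 mg/kg.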

Compound 4, dose for half-maximal effect: > 8 mg/kg
Compound 4: no number, only a limit; the forecaster's own chance of this, stated with the estimate: 25%; middle value at least 6.6-fold (0.82 log units) from the limit.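

In this assay, hydroxy in place of hydrogen on an aromatic carbon, para to a large group, gave an at least 16-fold higher number from compound 2 to compound 4 (1.20 log units; beyond the scatter), so this position on the benzyl group of compound 2 does not tolerate this change in this read-out. For compound 4 the value of > 8 mg/kg is a limit of the assay and not a number, which means that the step gives only the least size of the loss. The earlier compounds had shown a loss with a chloro and with a 2-phenylethenyl group, and with this hydroxy all three departures from the plain benzyl of compound 2 now end at limits, while the steps among compound 1, compound 3 and compound 4 cannot be read.

Nothing shown gives a cause for this loss, whether in the hydrogen-bond donor or acceptor that the hydroxy brings or in anything else. Going by these compounds, it also stays open whether a methoxy, an amine or a fluoro in place of the same hydrogen would keep the value of compound 2, and so whether the loss belongs to the hydroxy itself or to any group at this position.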